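This account rests on a few compounds, and the source may have more. Where it says the series, first, only, none or still open, it means among the compounds named here.

The measured compounds:
compound 1, `CN(C)CCn1cnnc1-c1cc(Oc2ccc(NC(=O)N/N=C/c3ccccc3)cc2F)ccn1`, 1120 nM
compound 2, `CN(C)CCn1cnnc1-c1cc(Oc2ccc(NC(=O)N/N=C/c3ccc(F)cc3)cc2F)ccn1`, 1370 nM
compound 3, `CN(C)CCn1cnnc1-c1cc(Oc2ccc(NC(=O)N/N=C/c3ccc(F)cc3F)cc2F)ccn1`, 960 nM

All three were tested in a functional assay on HT-29 cells (Homo sapiens) for cytotoxicity, read by MTT assay, with a stated time of 72 h; a lower number here means a stronger inhibitor, a higher number a weaker inhibitor. Compound 3 sits within the scatter of both others: the step of a 1.2-fold lower number from compound 1 to compound 3 (0.07 log units; within the scatter) and the step of a 1.4-fold lower number from compound 2 to compound 3 (0.15 log units; within the scatter) are each too small to count as a difference, so none of the three can be called more or less potent than another.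

Compound 4, `CN(C)CCn1cnnc1-c1cc(Oc2ccc(NC(=O)N/N=C/c3cc(Br)c(O)c(Br)c3)cc2F)ccn1`, has not been measured. It differs from compound 3 by 3,5-dibromo-4-hydroxyphenyl in place of 2,4-difluorophenyl on a carbon with a double bond to nitrogen. For the measured compounds named here, no measured step involves this group, so only the ring swaps made so far can be used as a guide: fluoro for hydrogen in a 1.2-fold higher number from compound 1 to compound 2 (0.09 log units; within the scatter) and a 1.4-fold lower number from compound 2 to compound 3 (0.15 log units; within the scatter), and the whole-ring swap a 1.2-fold lower number from compound 1 to compound 3 (0.07 log units; within the scatter), each within the scatter. On that basis compound 4 is expected to show a step of a 1.0-fold higher number from compound 3 to compound 4 (0.02 log units; within the scatter), that is nothing beyond the scatter. In this assay compound 4 is therefore estimated at 1000 nM, with a range from 400 nM to 2500 nM.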

Compound 4, half-maximal inhibitory concentration: 2670 nM
For compound 4 the middle estimate is 2.7-fold (0.43 log units) below the measured one, outside the stated range (above it).
By their numbers in this assay, from the lowest: compounds 3, 1, 2 and 4 (each within the scatter of the next, the first and the last beyond it).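

In this assay, the ring on the carbon with a double bond to nitrogen can move the number beyond the scatter, which none of the earlier ring swaps did: 3,5-dibromo-4-hydroxyphenyl gives a 2.8-fold higher number from compound 3 to compound 4 (0.44 log units; beyond the scatter) and a 2.4-fold higher number from compound 1 to compound 4 (0.38 log units; beyond the scatter). The effect is modest and does not hold against every earlier ring, since the step against 4-fluorophenyl, a 1.9-fold higher number from compound 2 to compound 4 (0.29 log units; within the scatter), does not separate those two compounds. Nothing available bears on why the number moves with this change.

The swap brings in the hydroxyl and the two bromines together, so the compounds shown leave open whether a ring carrying only the hydroxyl or only the bromines would read like compound 4. Also open, on these data alone, is how a ring bearing an amine or a carboxylic acid would read in this assay.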